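Adding a 3-Cyanophenyl Group to Compound 1

The compounds below may be only part of what the source reports. "The series", "measured", "known", "first", "only" and "open" are said of these compounds alone.

Measured compounds:
compound 1 `O=C(CCc1cccc2c1B(O)OC2)Nc1ccccc1`: 230 nM
compound 2 `C#Cc1ccc(NC(=O)CCc2cccc3c2B(O)OC3)cc1`: 6600 nM
compound 3 `O=C(CCc1cccc2c1B(O)OC2)Nc1ccc(-c2ccccc2)cc1`: 8800 nM

These three compounds share one core and differ only in what is attached to the outer aromatic ring of the anilide. In a functional assay on MDA-MB-231 cells (Homo sapiens) for antiproliferative activity, read by MTT assay, with a stated time of 72 h (on this read-out lower numbers stand for stronger inhibition and higher numbers for weaker inhibition), compound 1 gives the lowest number of the three, and both of its neighbours lie well away from it: a 29-fold higher number from compound 1 to compound 2 (1.46 log units; beyond the scatter) and a 38-fold higher number from compound 1 to compound 3 (1.58 log units; beyond the scatter). Between compound 2 and compound 3 there is little to separate: a 1.3-fold higher number from compound 2 to compound 3 (0.12 log units; within the scatter).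

Compound 4 `N#Cc1cccc(-c2cccc(NC(=O)CCc3cccc4c3B(O)OC4)c2)c1` has not yet been tested. It differs from compound 1 as follows: 3-cyanophenyl in place of hydrogen on an aromatic carbon. The new group sits on an aromatic carbon of a six-membered aromatic ring of carbon only, meta to a large group.

The two steps that bear on this change are the ones in which hydrogen on that same aromatic ring was replaced by ethynyl or by phenyl, and both were large increases in this assay. Compound 4 carries a 3-cyanophenyl group, itself containing a six-membered aromatic ring and a triple bond, so a step of similar size in the same direction is expected: a 26-fold higher number from compound 1 to compound 4 (1.42 log units; beyond the scatter). Compound 4 is therefore estimated at 6000 nM, within a range from 1500 nM to 25000 nM.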

Compound 4, half-maximal inhibitory concentration: 110 nM
Beside the measured number, compound 4's estimate is 55-fold (1.74 log units) above it; the measured number lies below the stated range.
By their numbers in this assay, from the lowest: compound 4; then compound 1; then compounds 2 and 3 (each within the scatter of the next).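

In this assay, among these compounds, the step of a 2.1-fold lower number from compound 1 to compound 4 (0.32 log units; beyond the scatter) runs in the opposite direction to the earlier steps of a 29-fold higher number from compound 1 to compound 2 (1.46 log units; beyond the scatter) and a 38-fold higher number from compound 1 to compound 3 (1.58 log units; beyond the scatter), so a substituent on this outer ring need not raise the number. The 3-cyanophenyl group, which sits meta to a large group, adds a six-membered aromatic ring and a triple bond, and the number still falls, if only modestly. Having an aromatic ring or a triple bond in the new group therefore does not by itself bring a large rise across these compounds, although compound 2 and compound 3 show that such a rise can occur, and nothing in the data presented explains the difference.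

On these data alone, the three substituted compounds differ both in the group and in the carbon that carries it, so it remains open which of the two matters more, and whether the nitrile contributes at all. A plain phenyl at the carbon used in compound 4, or 3-cyanophenyl at the carbon that carries phenyl in compound 3, would begin to separate these, and a carboxylic acid or an amine at either carbon would show how far the trend extends.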